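From a hydrazide to a dimethylamide on an ethenyl chain

A few compounds are considered here, and "the series" means these few. Any claim that something is new, unique, unknown or untested is made for them only; others in the source may bear on it.

Compound 3 `NNC(=O)CCc1ccncc1-c1ccc2ccccc2c1` has no number of its own: in a functional assay on HCT-116 cells (Homo sapiens) for inhibition, read by MTT assay, with a stated time of 72 h (a lower number here means a stronger inhibitor of growth, a higher number a weaker inhibitor of growth), compound 3 gives > 30000 nM, which is the limit of > 30000 nM in this assay, at which 1 of the 3 values shown sits, and not a measured value. Its two neighbours do have numbers. Compound 1 `CNC(=O)CCc1ccncc1-c1ccc2ccccc2c1` gives 19300 nM in this assay, and compound 2 `CNC(=O)/C=C/c1ccncc1-c1ccc2ccccc2c1` gives 6550 nM. The step of an at least 1.5-fold higher number from compound 1 to compound 3 (0.19 log units; that floor lies within the scatter) stays within the scatter, whereas an at least 4.5-fold higher number from compound 2 to compound 3 (0.66 log units; beyond the scatter) lies beyond it. Compound 4 `CN(C)C(=O)/C=C/c1ccncc1-c1ccc2ccccc2c1` differs from compound 3 by 2-(dimethylcarbamoyl)ethenyl in place of 2-(aminocarbamoyl)ethyl on an aromatic carbon. Going by the values given here, two measured steps bear on this change: a 2.9-fold lower number from compound 1 to compound 2 (0.47 log units; beyond the scatter), which brought in the ethenyl link, and an at least 4.5-fold higher number from compound 2 to compound 3 (0.66 log units; beyond the scatter), which removed it while amino replaced methyl on the amide-type nitrogen. Compound 4 restores the ethenyl link, but carries two methyl groups on that nitrogen where compound 2 carries one, a change without measured precedent here. A step of an at least 3.3-fold lower number from compound 3 to compound 4 (0.52 log units; beyond the scatter) is therefore expected, landing near compound 2 because compound 2 gives 6550 nM. Compound 4 is expected to give 9000 nM, between 3000 nM and 30000 nM.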

Compound 4, concentration for 50% growth inhibition: 4540 nM
Estimate against measurement, compound 4: 2.0-fold (0.30 log units) above; measured number inside the range.
By their numbers in this assay, from the lowest: compounds 4 and 2 (each within the scatter of the next); then compound 1. At a limit, above all of these: compound 3.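

In this assay, a second methyl on the amide-type nitrogen of the ethenyl chain, a change new to this series, gives a 1.4-fold lower number from compound 2 to compound 4 (0.16 log units; within the scatter), so this position accepts the 2-(dimethylcarbamoyl)ethenyl group with no change beyond the scatter. Set against the two chains with no ethenyl link, that group gives a 4.3-fold lower number from compound 1 to compound 4 (0.63 log units; beyond the scatter) and an at least 6.6-fold lower number from compound 3 to compound 4 (0.82 log units; beyond the scatter). Compound 3 stands at a limit, so the second of these steps is only a floor: the limit of > 30000 nM in this assay, at which 1 of the 4 values shown sits.

Going by these compounds, what a 2-(dimethylcarbamoyl)ethyl chain would give stays open, and with it how much of the step from the 2-(methylcarbamoyl)ethyl chain belongs to the ethenyl link alone. Also open, on these data alone, is whether a carboxylic acid or a pyrrolidine amide on the ethenyl chain would hold these numbers.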